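The source may report more compounds than this note shows. Statements on the series, on what has been measured and on what is new or still open speak of the compounds shown alone.

Working notes on the series.

Going by the values given here, compound 2 `COc1ccc(C(=O)/C=C/c2cc(-c3cc(OC)c(OC)c(OC)c3)n[nH]2)cc1OC` is the higher of the two numbers so far in a functional assay on T47D cells (Homo sapiens) for cytotoxicity, read by sulforhodamine B assay, with a stated time of 48 h, tested at 100 uM (a higher number here means a weaker effect of the compound at the concentration tested, a lower number a stronger effect), where compound 2 gives -46%. Among the compounds with values here, the only other measured compound, compound 1 `COc1cc(-c2cc(/C=C/C(=O)c3ccc(N)cc3)[nH]n2)cc(OC)c1OC`, gives -47% in this assay, and the two values lie within the usual scatter of each other, so neither can be called the stronger.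

The next compound, compound 3 `COc1ccc(C(=O)/C=C/c2cc(-c3cc(OC)c(OC)c(OC)c3)n[nH]2)cc1`, differs from compound 2 in one place: hydrogen in place of methoxy on an aromatic carbon. Within the data shown here, the aryl ring carrying the change is the same ring that was exchanged in the one measured step, a number 1 percentage points higher from compound 1 to compound 2 (within the scatter), where replacing 4-aminophenyl by 3,4-dimethoxyphenyl on the carbonyl carbon moved the read-out by no more than the scatter. That step is the only one that bears on the present change, and it gives no indication that the aryl on the carbonyl carbon shifts the number in this assay at this concentration.

For compound 3 the expected step in this assay is therefore a number 1 percentage points higher from compound 2 to compound 3 (within the scatter), none beyond the scatter. Compound 3 is expected to give -45%, within a range from -62% to -25%.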

Compound 3, a percentage reported as activity, at one concentration (the size of the read-out at that concentration, not a potency): -9%
Estimate against measurement, compound 3: 36 percentage points below; the whole stated range lies below it.
By their numbers in this assay, from the lowest: compounds 1 and 2 (each within the scatter of the next); then compound 3.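

In this assay, the change from 3,4-dimethoxyphenyl to 4-methoxyphenyl gives a number 37 percentage points higher from compound 2 to compound 3 (beyond the scatter) and so a clearly weaker effect at the concentration tested. Going by these compounds alone, the aryl on the carbonyl carbon therefore does affect this read-out, which the first step between compounds could not show: losing a single methoxy ortho to a methoxy group is enough to change the number. Methoxy in place of amino gives a number 38 percentage points higher from compound 1 to compound 3 (beyond the scatter) as well, so the 4-methoxyphenyl compound stands apart from both the 4-aminophenyl and the 3,4-dimethoxyphenyl compounds, and nothing available explains this difference.

The compounds shown leave open whether the vacated aromatic carbon needs methoxy itself or would accept another group, such as a hydroxyl, a chlorine atom or the longer ethoxy chain. Also open, as far as these compounds go, is whether the weaker effect seen at this single concentration would also appear at other concentrations, and whether an amine added to the 4-methoxyphenyl ring would bring the number back towards those of compound 1 and compound 2.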